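The compounds below may be only part of what the source reports. "The series", "measured", "known", "first", "only" and "open" are said of these compounds alone.

Measured compounds:
- compound 1 `COc1ccc(/C=C/C(=O)Nc2cc(C(=O)c3cc(OC)c(OC)c(OC)c3)ccc2OC)cc1`: 11800 nM
- compound 2 `COc1cccc(/C=C/C(=O)Nc2cc(C(=O)c3cc(OC)c(OC)c(OC)c3)ccc2OC)c1`: 4300 nM
- compound 3 `COc1ccc(C(=O)c2cc(OC)c(OC)c(OC)c2)cc1NC(=O)/C=C/c1ccc(F)cc1`: 300 nM

In a functional assay on ME-180 cells (Homo sapiens) for cytotoxicity, read by MTT assay, with a stated time of 72 h (on this read-out higher numbers stand for weaker inhibition and lower numbers for stronger inhibition), compound 3 holds the lowest number of the three. The steps that reach it are a 14-fold lower number from compound 2 to compound 3 (1.16 log units; beyond the scatter) and a 39-fold lower number from compound 1 to compound 3 (1.59 log units; beyond the scatter), both beyond the scatter, so compound 3 is the strongest of the measured set. Within the methoxy pair the move is a 2.7-fold lower number from compound 1 to compound 2 (0.44 log units; beyond the scatter).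

Compound 4 `COc1ccc(C(=O)c2cc(OC)c(OC)c(OC)c2)cc1NC(=O)/C=C/c1ccc(C(F)(F)F)cc1` differs from compound 3 by trifluoromethyl in place of fluoro on an aromatic carbon, on an aromatic carbon of a six-membered aromatic ring of carbon only, para to a large group. Among the compounds with values here, no measured step swaps fluoro for trifluoromethyl. Within the data shown here, the steps that bear on this carbon are a 39-fold lower number from compound 1 to compound 3 (1.59 log units; beyond the scatter) and a 14-fold lower number from compound 2 to compound 3 (1.16 log units; beyond the scatter), both large, which show that the substituent here moves the number strongly, but neither tells the direction for a trifluoromethyl group. A step of moderate size is therefore expected, more likely upward than downward, as a 1.8-fold higher number from compound 3 to compound 4 (0.26 log units; within the scatter). For compound 4 the estimate in this assay is 550 nM, within 120 nM to 2500 nM.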

Compound 4, half-maximal inhibitory concentration: 800 nM
Estimate against measurement, compound 4: 1.5-fold (0.16 log units) below; the range from low to high includes it.
By their numbers in this assay, from the lowest: compound 3; then compound 4; then compound 2; then compound 1.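

In this assay, within the data shown here, the first direct swap of fluoro for trifluoromethyl on this aromatic carbon, para to a large group, gives a 2.7-fold higher number from compound 3 to compound 4 (0.43 log units; beyond the scatter) and so separates the two groups, with fluoro keeping the lower number. The low numbers are still not confined to fluoro, since trifluoromethyl also gives a 5.4-fold lower number from compound 2 to compound 4 (0.73 log units; beyond the scatter) and a 15-fold lower number from compound 1 to compound 4 (1.17 log units; beyond the scatter) and thus stays clear of both methoxy compounds. Nothing available explains this order among the groups at this carbon.

Open, on these data alone, is whether another group at this carbon, such as chloro, nitrile or an amine, would give a number under that of compound 3. Also open, as far as these compounds go, is whether fluoro and trifluoromethyl keep this order on another carbon of the same ring, as the methoxy pair alone shows that the place of a substituent can move the number.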